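This account rests on a few compounds, and the source may have more. Where it says the series, first, only, none or still open, it means among the compounds named here.

Measured compounds:
compound 1 `COC(=O)CCn1cc(C(=O)C(=O)Nc2ccc(OC)nc2)c2ccccc21`, giving 168 nM in a functional assay on FaDu cells (Homo sapiens) for cytotoxicity, read by MTT assay, with a stated time of 72 h; a lower number here means that less compound is tolerated, a higher number that more compound is tolerated
compound 2 `CC(C)Oc1ccc(NC(=O)C(=O)c2cn(C(C)C)c3ccccc23)cn1`, giving 408 nM in this assay

Of the two numbers seen, compound 1 holds the lower one; compound 2 sits above it by a gap beyond the scatter. Compound 3 `COc1ccc(NC(=O)C(=O)c2cn(C(C)(C)COCC(=O)O)c3ccccc23)cn1` is not yet measured. It differs from compound 1 in one place: a group of 9 heavy atoms (6 carbon, 3 oxygen; no ring) in place of a group of 6 heavy atoms (4 carbon, 2 oxygen; no ring), on an aromatic nitrogen. The entering group is the larger of the two and carries 1 hydrogen-bond donor where the leaving group carries 0. Among the measured compounds shown here, no measured pair isolates a change of this kind, so the step rests on the structures alone: in this assay a rise beyond the scatter is expected, a 2.7-fold higher number from compound 1 to compound 3 (0.43 log units; beyond the scatter). Compound 3 is accordingly estimated at 450 nM, within 120 nM to 2000 nM.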

Compound 3, concentration lethal to 50% of the cells: > 10000 nM
Compound 3: a limit, no number; the forecaster's own chance of this, stated with the estimate: 5%; at least 22-fold (1.34 log units) between middle value and limit.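

In this assay, compound 3 gives > 10000 nM, which is a limit of the assay and not a number. Among the compounds shown here, on the aromatic nitrogen, putting the larger chain with its hydrogen-bond donor in place of 2-(methoxycarbonyl)ethyl produces an at least 59-fold higher number from compound 1 to compound 3 (1.77 log units; beyond the scatter), so this position is sensitive to the group it carries, something the earlier compounds, with no single change between them, could not show.

Going by these compounds, whether the step follows the hydrogen-bond donor or the rest of the entering chain remains open. A chain ending in an amine, or the same chain ending in a methyl ester, would bear on that question.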